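Dropping the benzyloxy group from a chalcone's benzoyl ring

A few compounds are considered here, and "the series" means these few. Any claim that something is new, unique, unknown or untested is made for them only; others in the source may bear on it.

The series is built on a common chalcone core. Compound 1 `O=C(/C=C/c1ccc(OCc2ccccc2)cc1)c1ccccc1` carries a benzyloxy group, and in a functional assay on HCT-116 cells (Homo sapiens) for antiproliferative activity, read by sulforhodamine B assay, with a stated time of 3 days, tested at 50 uM (on this read-out higher numbers stand for a stronger effect at the one concentration tested and lower numbers for a weaker effect), compound 1 gives 49.5%. Compound 2 `O=C(/C=C/c1ccc(Cl)cc1)c1ccccc1` carries a chloro group instead, and in this assay compound 2 gives 100%; the step of a number 50.5 percentage points higher from compound 1 to compound 2 (beyond the scatter) is the only one that can be read from the data. Compound 3 `O=C(/C=C/c1ccc(F)cc1)c1ccc(OCc2ccccc2)cc1` combines a fluoro group on one ring with a benzyloxy group on the other, but in this assay compound 3 gives "not determined" (no result reported), so it stands nowhere on the numbers shown.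

Compound 4 `O=C(/C=C/c1ccc(F)cc1)c1ccccc1` differs from compound 3 by hydrogen in place of benzyloxy on an aromatic carbon, placed on an aromatic carbon para to a large group. Among the measured compounds shown here, the one measured step concerns the same leaving group, benzyloxy, though on the other ring and with chloro rather than hydrogen entering; it was large and upward. That step, together with the value of compound 2 which shares the unsubstituted benzoyl ring with compound 4, points to a strong effect. Compound 4 is therefore expected to reach about 85%, with the estimate ranging from 55% to 100%.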

Compound 4, a percentage reported as inhibition, at one concentration (the size of the read-out at that concentration, not a potency): 100%
For compound 4 the middle estimate is 15 percentage points below the measured one; the measured number falls inside the stated range.
By their numbers in this assay, from the lowest: compound 1; then compounds 2 and 4 (each within the scatter of the next).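

In this assay, fluoro and chloro on the same aromatic carbon cannot be told apart, with no change at the digits printed from compound 2 to compound 4 (within the scatter). Fluoro in place of benzyloxy at that carbon brings a number 50.5 percentage points higher from compound 1 to compound 4 (beyond the scatter), the same size as the step to the chloro compound, so among these compounds the large rise is not tied to a single halogen. The steps that involve compound 3 cannot be read, and nothing available here bears on the cause of these differences.

Going by these compounds, it remains open whether hydrogen, a methoxy group, an amine or a carboxylic acid on that aromatic carbon would keep the read-out level with compound 2 and compound 4, or would leave it nearer compound 1. On these data alone, it also remains open whether compound 2 and compound 4 would still match at a lower concentration, as a single concentration gives the size of the effect there and not a potency.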